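A few compounds are considered here, and "the series" means these few. Any claim that something is new, unique, unknown or untested is made for them only; others in the source may bear on it.

Three compounds share one core and were tested in the same way. Compound 1 `Cc1cnc(Nc2ccc(S(C)(=O)=O)cc2)nc1Nc1nc2ccc(Cl)cc2s1` carries a chloro on an aromatic carbon; in a functional assay on PC-3 cells (Homo sapiens) for antiproliferative activity, read by MTT assay, with a stated time of 48 h (a higher number here means a weaker inhibitor, a lower number a stronger inhibitor), compound 1 gives 13400 nM. Compound 2 `Cc1cnc(Nc2ccc(S(C)(=O)=O)cc2)nc1Nc1nc2ccccc2s1` has hydrogen in place of that chloro. In this assay compound 2 gives > 50000 nM, which is a limit of the assay rather than a number. Compound 3 `Cc1cnc(Nc2ccc(S(N)(=O)=O)cc2)nc1Nc1nc2ccccc2s1` has amino in place of methyl on the sulfonyl sulfur. In this assay compound 3 gives > 50000 nM, again a limit. The step of an at least 3.7-fold higher number from compound 1 to compound 2 (0.57 log units; beyond the scatter) is therefore readable only as a lower bound, and a step that the two limits leave unreadable from compound 2 to compound 3 cannot be sized at all, since two of the three values sit at the limit of > 50000 nM in this assay, at which 2 of the 3 values shown sit.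

Compound 4 `CS(=O)(=O)c1ccc(Nc2nccc(Nc3nc4ccccc4s3)n2)cc1` differs from compound 2 by hydrogen in place of methyl on an aromatic carbon. For the measured compounds named here, no measured step touches this position, so neither an at least 3.7-fold higher number from compound 1 to compound 2 (0.57 log units; beyond the scatter) nor a step that the two limits leave unreadable from compound 2 to compound 3 speaks to it directly. The step that the limit leaves unreadable from compound 2 to compound 4 is expected to be small, because compound 2 already sits at the limit of > 50000 nM in this assay, at which 2 of the 3 values shown sit, and a small methyl removal gives no reason shown here to expect a large move. Compound 4 is accordingly estimated at 60000 nM in this assay, within a range from 20000 nM to 200000 nM, most likely reported again as a limit.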

Compound 4, half-maximal inhibitory concentration: 1710 nM
The estimate for compound 4 lay 35-fold (1.55 log units) above the measured number; the whole stated range lies above it.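

In this assay, the position on the six-membered aromatic ring with 2 nitrogen proves far from silent: hydrogen in place of methyl gives an at least 29-fold lower number from compound 2 to compound 4 (1.46 log units; beyond the scatter). For the compounds shown here, none of the earlier steps touched this position, and they could not show that losing a single carbon atom here, with no ring, hydrogen-bond donor, hydrogen-bond acceptor or net charge involved, can move the number so far. Compound 2 stands at a limit of the assay and not at a number, so this step gives only the smallest size the change can have, and its true size may be larger because of that limit: the limit of > 50000 nM in this assay, at which 2 of the 4 values shown sit.

The compounds shown hold only methyl and hydrogen at this position, so it stays open how an ethyl, a methoxy, an amine or a fluoro there would compare. From the compounds shown here alone, it also stays open whether the chloro on the aromatic carbon, or the amino on the sulfonyl sulfur, would have the same effect in a compound with hydrogen at this position, since each of those changes appears here only with the methyl in place.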